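A few compounds are considered here, and "the series" means these few. Any claim that something is new, unique, unknown or untested is made for them only; others in the source may bear on it.

Working notes on the series around compound 1 `CC(C(=O)NCc1ccc(C(F)(F)F)nc1NC1CCCCC1)c1ccc(NS(C)(=O)=O)c(F)c1`. Among the measured compounds shown here, in a functional assay on CHO-K1 cells for antagonist activity at transient receptor potential cation channel subfamily V member 1 (Homo sapiens), read by FLIPR (on this read-out higher numbers stand for weaker inhibition and lower numbers for stronger inhibition), compound 1 gives 260 nM, the highest of the three numbers measured so far. Compound 2 `CCCCN(C)c1nc(C(F)(F)F)ccc1CNC(=O)C(C)c1ccc(NS(C)(=O)=O)c(F)c1` gives 21.3 nM in this assay, and compound 3 `CC(C(=O)NCc1ccc(C(F)(F)F)nc1N1CC=CCC1)c1ccc(NS(C)(=O)=O)c(F)c1` gives 12.1 nM. Both steps away from compound 1 are large and run the same way: a 12-fold lower number from compound 1 to compound 2 (1.09 log units; beyond the scatter), and a 21-fold lower number from compound 1 to compound 3 (1.33 log units; beyond the scatter). Between the two replacements themselves, a 1.8-fold lower number from compound 2 to compound 3 (0.25 log units; within the scatter).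

Compound 4 `CC(C(=O)NCc1ccc(C(F)(F)F)nc1N1CCC(O)CC1)c1ccc(NS(C)(=O)=O)c(F)c1` has not yet been measured in this assay. Relative to compound 1 the change is 4-hydroxypiperidin-1-yl in place of cyclohexylamino on an aromatic carbon. The steps from compound 1 to compound 2 and from compound 1 to compound 3 are the ones that bear on it, since each also exchanges the cyclohexylamino group for a group of about the same size on the same aromatic carbon, and each gave a large move toward lower numbers. For the measured compounds named here, the 4-hydroxypiperidin-1-yl group itself has no measured counterpart, so the range is kept wide. For compound 4 a step of a 10-fold lower number from compound 1 to compound 4 (1.02 log units; beyond the scatter) is expected. Compound 4 is therefore estimated at 25 nM, within a range from 8 nM to 80 nM.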

Compound 4, half-maximal inhibitory concentration: "not active" (no number reported)
For compound 4 the study gives words and no number; there is nothing to compare the estimate with.
By their numbers in this assay, from the lowest: compounds 3 and 2 (each within the scatter of the next); then compound 1.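

In this assay, among the compounds shown here, compound 4 is reported as "not active", in words and without a number, so no step from compound 1, compound 2 or compound 3 to compound 4 can be read. The compounds shown leave open how far 4-hydroxypiperidin-1-yl in place of cyclohexylamino moves the read-out. Nothing shown here bears on this result.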